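Toxicity notes: amide aryl swap on the shared core

The source may report more compounds than this note shows. Statements on the series, on what has been measured and on what is new or still open speak of the compounds shown alone.

Compound 2 `COc1ccc(-c2cnc(NC(=O)c3ccno3)n2C)cc1` is the parent of the step at hand. In a toxicity assay on THP-1 cells (Homo sapiens) for inhibition (on this read-out higher numbers stand for lower toxicity in this test and lower numbers for higher toxicity in this test), compound 2 reaches only a limit, > 100000 nM, and so sits at the upper end of the numbers shown; this is the limit of > 100000 nM in this assay, at which 1 of the 3 values shown sits. Compound 1 `Cn1c(-c2ccccc2Cl)cnc1NC(=O)c1ccc(F)cc1` likewise gives only a limit in this assay, > 50000 nM, which is the limit of > 50000 nM in this assay, at which 1 of the 3 values shown sits. Within the data shown here, compound 3 `Cn1c(-c2ccccc2[N+](=O)[O-])cnc1NC(=O)c1ccc(F)cc1` is the one compound with a number: in this assay compound 3 gives 31000 nM. Among the measured compounds shown here, the single measured step, an at least 1.6-fold lower number from compound 1 to compound 3 (0.20 log units; that floor lies within the scatter), is the only change with a reading, and its floor lies within the scatter.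

Compound 4 `COc1ccc(-c2cnc(NC(=O)c3cccc(OC)c3)n2C)cc1` differs from compound 2 by 3-methoxyphenyl in place of 1,2-oxazol-5-yl on a carbonyl carbon. For the measured compounds named here, no measured step touches this change: the step from compound 1 to compound 3 alters a substituent on the aryl carried by the shared core, not the group on the carbonyl carbon, so it gives no direction. All three measured values sit at or near the upper end of this assay, and nothing in the series points to a fall for compound 4. The expected step is therefore none beyond the scatter, a number no higher from compound 2 to compound 4 (the limit leaves the size open). Compound 4 is accordingly expected to give 100000 nM in this assay, with a range from 30000 nM to 300000 nM, most probably again reported only as a limit.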

Compound 4, half-maximal cytotoxic concentration: > 100000 nM
Compound 4: no number, only a limit; the forecaster's own chance of this, stated with the estimate: 70%; the middle value lies on the limit itself.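

In this assay compound 4 gives > 100000 nM as a limit only. Compound 2 likewise gives > 100000 nM as a limit only, so the step between the two cannot be read. The compounds shown leave open whether 3-methoxyphenyl in place of 1,2-oxazol-5-yl on a carbonyl carbon shifts the number at all, and in which direction.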